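This account rests on a few compounds, and the source may have more. Where it says the series, first, only, none or still open, it means among the compounds named here.

Measured so far in a functional assay on HT-29 cells (Homo sapiens) for inhibition, read by sulforhodamine B assay, with a stated time of 72 h; on this read-out higher numbers stand for weaker inhibition and lower numbers for stronger inhibition:
- compound 1, `COc1cc2c(Nc3ccc(OCc4cccc(F)c4)c(Cl)c3)ncnc2cc1OCCCCCn1ccnc1[N+](=O)[O-]`, gives 5040 nM.
- compound 2, `COc1cc2c(Nc3ccc(OCc4cccc(F)c4)c(Cl)c3)ncnc2cc1OCCCCCCn1ccnc1[N+](=O)[O-]`, reaches only the assay limit at > 50000 nM.
- compound 3, `COc1cc2c(Nc3cccc(Br)c3)ncnc2cc1OCCCn1ccnc1[N+](=O)[O-]`, gives 2820 nM.

Compounds 1 and 2 share a core and differ by (2-nitro-1H-imidazol-1-yl)methyl in place of 2-nitro-1H-imidazol-1-yl on a saturated chain carbon, five bonds along the chain from an oxygen on an aromatic ring. Across that change this assay moves by an at least 9.9-fold higher number from compound 1 to compound 2 (0.99 log units; beyond the scatter). The true size of this step is known only as a lower bound because compound 2 sits at the limit of > 50000 nM in this assay, at which 1 of the 3 values shown sits.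

Compound 3 carries a different core; the difference between the two cores is not broken down here. Its number in this assay and that of compound 1 lie within the scatter of each other, so no order between them is claimed.

Compound 4, `COc1cc2c(Nc3cccc(Br)c3)ncnc2cc1OCCCCn1ccnc1[N+](=O)[O-]`, is not yet measured. It differs from compound 3 by (2-nitro-1H-imidazol-1-yl)methyl in place of 2-nitro-1H-imidazol-1-yl on a saturated chain carbon, three bonds along the chain from an oxygen on an aromatic ring. This is the same kind of change as that from compound 1 to compound 2, but not the same: there the chain carbon sits five bonds along the chain from an oxygen on an aromatic ring, here three bonds.

For compound 4 in this assay the expectation is a step of a 3.2-fold higher number from compound 3 to compound 4 (0.50 log units; beyond the scatter), resting on the weakening seen across an at least 9.9-fold higher number from compound 1 to compound 2 (0.99 log units; beyond the scatter), tempered because the shorter chain of compound 3, at 2820 nM, is a different starting point. The estimate for compound 4 is 9000 nM, between 2500 nM and 40000 nM.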

Compound 4, half-maximal inhibitory concentration: 1430 nM
For compound 4 the middle estimate is 6.3-fold (0.80 log units) above the measured one; the whole stated range lies above it.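

In this assay the one added chain carbon does not carry over from one core to the other as a step of the same size: the same change on two cores in this assay, an at least 9.9-fold higher number (0.99 log units; beyond the scatter) from compound 1 to compound 2 and a 2.0-fold lower number (0.29 log units; within the scatter) from compound 3 to compound 4, at least 19-fold (1.29 log units) apart, beyond the scatter of two such steps

On the core of compound 3 the step is a 2.0-fold lower number from compound 3 to compound 4 (0.29 log units; within the scatter), so the longer chain gives no change there that can be told from the scatter.

This does not show that the core alone sets the outcome, as the two steps also differ in place, five bonds along the chain from an oxygen on an aromatic ring for the earlier one and three bonds for the new one, and compound 2 stands at a limit, which leaves the size of the earlier step known from one side only: the limit of > 50000 nM in this assay, at which 1 of the 4 values shown sits.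

The compounds shown leave open whether a longer chain on the core of compound 3 would lose activity in the way compound 2 does on its own core, and whether shorter chains on the core of compound 1 would behave like compound 3 and compound 4. All of them carry 2-nitro-1H-imidazol-1-yl at the chain end, so the read-out of an amine in that place remains an open comparison.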